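A Longer Chain on Compound 2: An Estimate

The source may report more compounds than this note shows. Statements on the series, on what has been measured and on what is new or still open speak of the compounds shown alone.

The numbers here come from an ADME assay on the whole organism with Oryza sativa as the target, tested at 1 uM; on this read-out higher numbers stand for a weaker effect at the one concentration tested and lower numbers for a stronger effect. Within the data shown here, compound 2 `CCCc1ccc(NC(=O)N[C@@H](C)c2ccccc2)cc1` gives 76%, the second highest of the three values known so far. Compound 3 `C[C@@H](NC(=O)Nc1ccccc1C(C)(C)C)c1ccccc1` stands higher, with 95%. Compound 1 `CCCc1ccc(NC(=O)N[C@H](C)c2ccccc2)cc1` stands far lower, at 31%. Among the measured compounds shown here, the only pair of measured compounds that differ in a single place gives the step of a number 45 percentage points higher from compound 1 to compound 2 (beyond the scatter), and it rests on (the fact that compounds 1 and 2 differ only in the configuration as drawn).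

Compound 4 `CCCCCCCc1ccc(NC(=O)N[C@@H](C)c2ccccc2)cc1` has not yet been measured. It differs from compound 2 in one place: butyl in place of hydrogen on a saturated chain carbon, three bonds along the chain from an aromatic carbon. For the measured compounds named here, none of the measured steps concerns a change of this kind, since the single step known is a change of configuration and not a lengthening of a chain. The expectation for compound 4 therefore leans on the value of compound 2 alone, and the expected step is a number 4 percentage points lower from compound 2 to compound 4 (within the scatter), meaning little movement beyond the scatter, though with considerable uncertainty in either direction. The three measured values run all the way from compound 1 to compound 3. The range given is accordingly wide. Compound 4 is expected to give 72%, somewhere between 40% and 95%.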

Compound 4, a percentage reported as activity, at one concentration (the size of the read-out at that concentration, not a potency): 99%
The estimate for compound 4 lay 27 percentage points below the measured number; the measured number lies above the stated range.
By their numbers in this assay, from the lowest: compound 1; then compound 2; then compounds 3 and 4 (each within the scatter of the next).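

In this assay, going from propyl to heptyl on this chain brings a number 23 percentage points higher from compound 2 to compound 4 (beyond the scatter), so the far end of the chain is not a place where carbons can be added freely: with butyl in place of hydrogen, the effect at the one concentration tested becomes weaker. Among these compounds, until now, the only single change on record was one of configuration, whereas here the configuration stays as drawn and the chain length alone shifts the read-out, showing that this part of the molecule matters as well. The information at hand gives no reason for this loss of effect, so the step can only be recorded as an observation.

From the compounds shown here alone, with only the propyl and heptyl chains to compare, it remains open whether the number climbs gradually through the butyl, pentyl and hexyl chains or jumps at one particular length, and whether a shorter ethyl chain or a chain ending in an amine or a carboxylic acid would move it the other way. Among the compounds shown here, it is also open whether the heptyl chain would cost as much on the opposite configuration, the one drawn in compound 1, which gives the strongest effect of the pair that differ only in configuration.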